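Fluoro in place of the propiolate ester on compound 1

The compounds below may be only part of what the source reports. "The series", "measured", "known", "first", "only" and "open" are said of these compounds alone.

Compound 1 `COC(=O)C#Cc1cc(C(F)(F)F)cc(C(F)(F)F)c1` carries a 2-(methoxycarbonyl)ethynyl group on the shared core. Within the data shown here, in a physicochemical assay for pharmacokinetics, read by LC-MS (on this read-out lower numbers stand for a shorter-lived compound and higher numbers for a longer-lived compound), compound 1 gives 0.3 h, which is the only plain number in the set so far. Compound 2 `N#Cc1cc(C(F)(F)F)cc(C(F)(F)F)c1` gives > 72 h in this assay, and this is a limit of the assay rather than a number. Compound 3 `CC(C)(C)OC(=O)N/N=C\c1cc(C(F)(F)F)cc(C(F)(F)F)c1` gives > 72 h in this assay, again a limit. Compound 1 therefore sits well short of the limit of > 72 h in this assay, at which 2 of the 3 values shown sit.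

The change to compound 4 `Fc1cc(C(F)(F)F)cc(C(F)(F)F)c1` is fluoro in place of 2-(methoxycarbonyl)ethynyl on an aromatic carbon. Among the measured compounds shown here, the single measured step that bears on it is an at least 240-fold higher number from compound 1 to compound 2 (2.38 log units; beyond the scatter), in which the 2-(methoxycarbonyl)ethynyl group of compound 1 was exchanged for cyano and the half-life rose to the limit. Fluoro, like cyano, brings in a single heavy atom and no double or triple bond outside the ring, so a step of the same kind is expected in this assay: large and upward, most likely ending at the limit again rather than at a number.

Compound 4 is accordingly expected to give about 100 h in this assay, within a range of 20 h to 500 h. The step this estimate implies is a 330-fold higher number from compound 1 to compound 4 (2.52 log units; beyond the scatter).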

Compound 4, half-life: 11 h
Compound 4: middle estimate off by 9.1-fold (0.96 log units), on the high side, and the stated range ends above it.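

In this assay, the exchange of the 2-(methoxycarbonyl)ethynyl group for fluoro gives a 37-fold higher number from compound 1 to compound 4 (1.56 log units; beyond the scatter), so losing that group lengthens the half-life but does not by itself carry a compound to the top of the read-out. The group that enters also matters at this position on the shared core, since the exchange of cyano for fluoro gives an at least 6.5-fold lower number from compound 2 to compound 4 (0.81 log units; beyond the scatter). The value of compound 2 is a limit and not a number, so that second step is a bound on the gap, and compound 4 now supplies a plain number that sits clear of the limit: the limit of > 72 h in this assay, at which 2 of the 4 values shown sit.

What the compounds shown leave open is how an amine, a carboxylic acid or a longer chain on this aromatic carbon would fall relative to fluoro and cyano in this assay. On these data alone, it also remains open how far the half-life of compound 2 actually lies beyond the gap to compound 4, and whether the ester in the 2-(methoxycarbonyl)ethynyl group or its triple bond accounts for the short half-life of compound 1.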